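The source may report more compounds than this note shows. Statements on the series, on what has been measured and on what is new or still open speak of the compounds shown alone.

Compound 3, `Cn1nnnc1SCC(=O)N/N=c1/scc(-c2ccc(C#N)cc2)n1-c1ccccc1`, was tested in an ADME assay on NIH3T3 cells (Mus musculus) for cytotoxicity, read by MTT assay, with a stated time of 24 h (on this read-out lower numbers stand for stronger inhibition and higher numbers for weaker inhibition), and gave 213 ug/mL. Among the three compounds measured so far it stands second highest, and its distance to each of the other two lies within the scatter. Compound 1, `O=C(CSc1nnnn1-c1ccccc1)N/N=c1/scc(-c2ccccc2)n1-c1ccccc1`, gave 417 ug/mL, and compound 2, `O=C(CSc1nnnn1-c1ccccc1)N/N=c1/scc(-c2ccc(F)cc2)n1-c1ccccc1`, gave 207 ug/mL. For the measured compounds named here, the one step that can be read between measured compounds, a 2.0-fold lower number from compound 1 to compound 2 (0.30 log units; within the scatter), concerns a fluoro in place of hydrogen on an aromatic carbon and therefore says nothing about the change now in question.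

Compound 4 is `N#Cc1ccc(-c2cs/c(=N/NC(=O)CSc3nnnn3-c3ccccc3)n2-c2ccccc2)cc1`. Against compound 3 it shows (phenyl in place of methyl on an aromatic nitrogen). Compounds 1 and 2 already carry the 1-phenyl-1H-tetrazol-5-yl group while compound 3 carries the 1-methyl-1H-tetrazol-5-yl group, and all three sit within the scatter of one another, so no step beyond the scatter is expected from this change. For compound 4 the expected step is a 1.2-fold higher number from compound 3 to compound 4 (0.07 log units; within the scatter), and its value in this assay is estimated at 250 ug/mL, within a range from 120 ug/mL to 500 ug/mL.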

Compound 4, half-maximal inhibitory concentration: 453 ug/mL
Beside the measured number, compound 4's estimate is 1.8-fold (0.26 log units) below it; low and high end bracket the measured number.
By their numbers in this assay, from the lowest: compounds 2, 3, 1 and 4 (each within the scatter of the next, the first and the last beyond it).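

For the compounds shown here, putting phenyl in place of methyl on the aromatic nitrogen gives the first step beyond the scatter in this assay, a modest one: a 2.1-fold higher number from compound 3 to compound 4 (0.33 log units; beyond the scatter), which on this read-out means weaker inhibition. With phenyl on that nitrogen, cyano in place of fluoro on the aromatic carbon also lies beyond the scatter, at a 2.2-fold higher number from compound 2 to compound 4 (0.34 log units; beyond the scatter), whereas cyano in place of hydrogen stays within it, at a 1.1-fold higher number from compound 1 to compound 4 (0.04 log units; within the scatter), so the two changes at that carbon do not read alike. No measured evidence here bears on what lies behind these steps.

On these data alone, the phenyl-for-methyl step rests on a single pair, both carrying cyano, so whether it holds with hydrogen or fluoro on that carbon remains open. Also open, as far as these compounds go, is how an ethyl or benzyl group on the same nitrogen would compare.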